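Swapping a methylphenyl for pyridinyl on the amide side chain

This account rests on a few compounds, and the source may have more. Where it says the series, first, only, none or still open, it means among the compounds named here.

Of the compounds shown here, three that share one core have been measured in an assay on microsomes from liver for inhibition of 3-hydroxy-3-methylglutaryl-coenzyme A reductase (Rattus norvegicus); on this read-out lower numbers stand for stronger inhibition and higher numbers for weaker inhibition. Compound 1 `CC(C)c1c(C(=O)NCC2CCCCC2)nn(-c2ccc(F)cc2)c1OC[C@@H](O)C[C@@H](O)CC(=O)O` gives 17 nM. Compound 2 `Cc1cccc(CNC(=O)c2nn(-c3ccc(F)cc3)c(OC[C@@H](O)C[C@@H](O)CC(=O)O)c2C(C)C)c1` gives 4.9 nM, and compound 3 `Cc1ccccc1CNC(=O)c1nn(-c2ccc(F)cc2)c(OC[C@@H](O)C[C@@H](O)CC(=O)O)c1C(C)C` gives 17 nM. Compound 3 therefore stands level with compound 1 at the highest of the three numbers; its only wider gap is to compound 2, seen as a 3.5-fold higher number from compound 2 to compound 3 (0.54 log units; beyond the scatter). The same gap appears from the other side as a 3.5-fold lower number from compound 1 to compound 2 (0.54 log units; beyond the scatter), while no change at the digits printed from compound 1 to compound 3 (within the scatter). Together these steps show that varying the group on the saturated chain carbon bound to the amide-type nitrogen moves the number by modest amounts, in both directions.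

The next compound, compound 4 `CC(C)c1c(C(=O)NCc2ccccn2)nn(-c2ccc(F)cc2)c1OC[C@@H](O)C[C@@H](O)CC(=O)O`, differs from compound 3 in one place: pyridin-2-yl in place of 2-methylphenyl on a saturated chain carbon bound to an amide-type nitrogen. Among the compounds with values here, no measured step puts a ring containing a nitrogen at this position, so there is no direct precedent for this change. What the measured steps do show is that the read-out in this assay is not very sensitive to the group at this place. A step of a 1.2-fold higher number from compound 3 to compound 4 (0.07 log units; within the scatter) is therefore expected, which means no shift clearly beyond the scatter. Compound 4 is expected to give 20 nM, with a range from 8 nM to 50 nM.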

Compound 4, half-maximal inhibitory concentration: 25 nM
Compound 4: the middle estimate sits 1.3-fold (0.10 log units) below what was measured; measured number inside the range.
By their numbers in this assay, from the lowest: compound 2; then compounds 1, 3 and 4 (each within the scatter of the next).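

In this assay, a ring containing a nitrogen now stands on the saturated chain carbon bound to the amide-type nitrogen, and the number stays within the scatter of two quite different groups: pyridin-2-yl in place of 2-methylphenyl gives a 1.5-fold higher number from compound 3 to compound 4 (0.17 log units; within the scatter), and pyridin-2-yl in place of cyclohexyl gives a 1.5-fold higher number from compound 1 to compound 4 (0.17 log units; within the scatter). Only 3-methylphenyl stands apart, as pyridin-2-yl in its place gives a 5.1-fold higher number from compound 2 to compound 4 (0.71 log units; beyond the scatter), so compound 2 keeps the lowest number of the four, with clear gaps to each of the others. Nothing measured here explains why the numbers fall this way.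

A plain phenyl ring at this place would show how pyridin-2-yl compares with a carbon-only ring that has no methyl, and so separate the ring nitrogen from the methyl group in these comparisons. On these data alone, it also remains open whether pyridin-3-yl, which has its ring nitrogen in a different place, would give a number closer to that of compound 2 or to that of compound 4.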